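Two dimethylphenyl isomers on the ring nitrogen

The source may hold more compounds than are shown below. What is called first, only, known or untested is meant among the compounds shown, and "the series" means these compounds.

Compounds measured in a functional assay on HL-60 cells (Homo sapiens) for inhibition, read by MTT assay, with a stated time of 72 h; a lower number here means a stronger inhibitor, a higher number a weaker inhibitor:
compound 1 `Cc1nc(-c2ccccc2)c(C(=O)N2CCN(c3cccc(Cl)c3Cl)CC2)o1`, 133 nM
compound 3 `Cc1cc(C)cc(N2CCN(C(=O)c3oc(C)nc3-c3ccccc3)CC2)c1`, 34.5 nM
compound 2 `Cc1nc(-c2ccccc2)c(C(=O)N2CCN(c3ccc(F)cc3)CC2)o1`, whose result is a limit of the assay, > 1000 nM

Compound 3 gives the lowest of the two numbers shown; its nearest neighbour is compound 1, with a 3.9-fold lower number from compound 1 to compound 3 (0.59 log units; beyond the scatter). Compound 4 `Cc1nc(-c2ccccc2)c(C(=O)N2CCN(c3ccc(C)c(C)c3)CC2)o1` is the unmeasured isomer: 3,4-dimethylphenyl in place of 3,5-dimethylphenyl on an amine nitrogen in a ring. Among the measured compounds shown here, the steps that bear on this place are an at least 7.5-fold higher number from compound 1 to compound 2 (0.87 log units; beyond the scatter) and an at least 28-fold lower number from compound 2 to compound 3 (1.46 log units; beyond the scatter), both exchanges of one aryl group for another, and a 3.9-fold lower number from compound 1 to compound 3 (0.59 log units; beyond the scatter). None of them keeps the same two methyl groups and merely relocates one, so the expected step is small. Compound 4 is expected to give 50 nM, within 15 nM to 170 nM, a step of a 1.4-fold higher number from compound 3 to compound 4 (0.16 log units; within the scatter), within the scatter.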

Compound 4, half-maximal inhibitory concentration: 43 nM
Estimate against measurement, compound 4: 1.2-fold (0.07 log units) above, within the range that was stated.
By their numbers in this assay, from the lowest: compounds 3 and 4 (each within the scatter of the next); then compound 1. At a limit, above all of these: compound 2.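

In this assay, moving one methyl group gives a 1.2-fold higher number from compound 3 to compound 4 (0.10 log units; within the scatter), so the 3,5-dimethylphenyl and 3,4-dimethylphenyl isomers cannot be told apart here. Compound 4 also stands clear of the other two aryl groups, with a 3.1-fold lower number from compound 1 to compound 4 (0.49 log units; beyond the scatter) and an at least 23-fold lower number from compound 2 to compound 4 (1.36 log units; beyond the scatter), so the result for compound 3 is not confined to a single methyl arrangement. The second of these steps has only a bound, as the result for compound 2 is a limit: the limit of > 1000 nM in this assay, at which 1 of the 4 values shown sits.

The compounds shown leave open whether an unsubstituted phenyl group or a pyridine ring on that nitrogen would give numbers of this size.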